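Working notes: cytotoxicity across the substituent change at one aromatic carbon

The source may hold more compounds than are shown below. What is called first, only, known or untested is meant among the compounds shown, and "the series" means these compounds.

Measured compounds:
compound 1 `c1ccc(-c2ccc(Cn3cncc3CNc3cccc(-c4ccccc4)c3)cc2)cc1` — 10000 nM
compound 2 `O=C(OC1CCCCC1)c1ccc(NCc2cncn2Cc2ccc(-c3ccccc3)cc2)cc1-c1ccccc1` — > 10000 nM (a limit)
compound 3 `c1ccc(-c2ccc(Cn3cncc3CNc3ccc(-c4cncs4)c(-c4ccccc4)c3)cc2)cc1` — > 1000 nM (a limit)

In a toxicity assay on NIH3T3 cells (Mus musculus) for cytotoxicity, read by resazurin assay (a higher number here means that more compound is needed for the effect, a lower number that less compound is needed), compound 1 gives 10000 nM. Compound 2 reaches only a limit in this assay, > 10000 nM. Compound 3 likewise stands at a limit, > 1000 nM; of the three values shown, one other is also a limit, so compound 3 cannot be ranked against its neighbours beyond the limit itself. The steps among the measured compounds are a number no lower from compound 1 to compound 2 (the limit leaves the size open), a step that the limit leaves unreadable from compound 1 to compound 3 and a step that the two limits leave unreadable from compound 2 to compound 3. None of them is readable in size, because the limit of > 1000 nM in this assay, at which 1 of the 3 values shown sits, and the limit of > 10000 nM in this assay, at which 1 of the 3 values shown sits, cap the values of compound 3 and compound 2.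

The next compound, compound 4 `CC(=O)c1ccc(NCc2cncn2Cc2ccc(-c3ccccc3)cc2)cc1-c1ccccc1`, differs from compound 3 by acetyl in place of 1,3-thiazol-5-yl on an aromatic carbon. Among the measured compounds shown here, the steps that bear on this position, from compound 1 to compound 3 and from compound 2 to compound 3, both end at a limit and give no readable size, so no step beyond the usual scatter is expected in this assay from this change. Compound 4 is therefore expected to remain weakly cytotoxic, with an estimated value of 10000 nM (range 3000 nM to 30000 nM). The expected step is a step that the limit leaves unreadable from compound 3 to compound 4, and a further limit rather than a number is considered likely.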

Compound 4, half-maximal effective concentration: > 10000 nM
Compound 4 gave a limit, no number; the forecaster's own chance of this, stated with the estimate: 60%; the middle value sits exactly at the limit.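

In this assay, acetyl on this aromatic carbon, ortho to a phenyl group, is a second group after the cyclohexyloxycarbonyl of compound 2 that ends at a limit rather than a number, and unlike that group it has no ring. Among the compounds shown here, with hydrogen at this carbon, compound 1 holds the only number in the set, and the change to acetyl gives a number no lower from compound 1 to compound 4 (the limit leaves the size open). Compound 3 remains at a limit of > 1000 nM, so 1,3-thiazol-5-yl cannot be placed against acetyl.

As far as these compounds go, none of the new steps can be read in size, and whether any change at this carbon gives a number lower than that of compound 1 stays open: the limit of > 10000 nM in this assay, at which 2 of the 4 values shown sit. An amine or a carboxylic acid at this carbon could show whether a number can be reached here at all in this assay.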